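The source may report more compounds than this note shows. Statements on the series, on what has been measured and on what is new or still open speak of the compounds shown alone.

Series notes, cytotoxicity. Compound 1 `Brc1cccc(/N=N/N2CCCCC2)c1` and compound 2 `Cc1c(/N=N/c2cccc(C(F)(F)F)c2)ccc(NC[C@@H]2CCCN3CCCC[C@H]23)c1C` have both been run in an ADME assay on BHK-21 cells (Mesocricetus auratus) for cytotoxicity, read by MTT assay, with a stated time of 96 h; a lower number here means that less compound is tolerated, a higher number that more compound is tolerated. For compound 1 the result is a limit of the assay, > 100000 nM. For compound 2 the result is likewise a limit, >= 100000 nM, so compound 2 stands at the ceiling of what this assay can report (the limit of >= 100000 nM in this assay, at which 1 of the 2 values shown sits). Compound 3 `Cc1c(/N=N/c2ccccc2)ccc(NC[C@@H]2CCCN3CCCC[C@H]23)c1C` is the next entry, not yet measured. The change from compound 2 is hydrogen in place of trifluoromethyl on an aromatic carbon. For the measured compounds named here, no measured step is on hand for this series, so no size beyond the scatter is expected: the step from compound 2 to compound 3 in this assay is estimated as a number no higher from compound 2 to compound 3 (the limit leaves the size open). Compound 3 is therefore expected near 100000 nM, within 30000 nM to 300000 nM.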

Compound 3, half-maximal cytotoxic concentration: 47000 nM
The estimate for compound 3 lay 2.1-fold (0.33 log units) above the measured number, and the stated range covers the measured number.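

In this assay, the aromatic position meta to a large group is not neutral to this change: the swap of trifluoromethyl for hydrogen gives an at least 2.1-fold lower number from compound 2 to compound 3 (0.32 log units; beyond the scatter). For the compounds shown here, compound 3 also gives the first value that is a number and not a limit. The true size of the step stays unknown, as its starting point is only a limit: the limit of >= 100000 nM in this assay, at which 1 of the 3 values shown sits.

On these data alone, whether a chlorine, a methyl or a methoxy group at this position would track compound 2 or compound 3 remains open. Also open, as far as these compounds go, is how far the number for compound 2 lies beyond its limit.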